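Adding a ring hydroxy to the long-chain compound

The source may hold more compounds than are shown below. What is called first, only, known or untested is meant among the compounds shown, and "the series" means these compounds.

The study concerns three close relatives of one core. Compound 1 `CCCCC#Cc1cc2cn([C@@H]3O[C@H](CO)[C@@H](O)[C@H]3O)c(=O)nc2o1` carries a hex-1-ynyl chain and the 3,4-dihydroxy-5-(hydroxymethyl)oxolan-2-yl ring. In a functional assay on HEL cells (Homo sapiens) for cytotoxicity (on this read-out lower numbers stand for higher toxicity in this test and higher numbers for lower toxicity in this test), compound 1 gives only a limit of > 144000 nM, not a number. Among the measured compounds shown here, compound 2 `CCCCCCCCCCC#Cc1cc2cn([C@H]3C[C@H](O)[C@@H](CO)O3)c(=O)nc2o1` carries the dodec-1-ynyl chain and the 4-hydroxy-5-(hydroxymethyl)oxolan-2-yl ring; in this assay compound 2 gives 30000 nM, the single real number among the two results. The other result, that of compound 1, is the one noted in the limit of > 144000 nM in this assay, at which 1 of the 2 values shown sits. Compound 3 `CCCCCCCCCCC#Cc1cc2cn([C@@H]3O[C@H](CO)[C@@H](O)[C@H]3O)c(=O)nc2o1` has not yet been measured. It keeps the dodec-1-ynyl chain of compound 2 and differs from it in one place: hydroxy in place of hydrogen on a saturated ring carbon. For the measured compounds named here, no step between two measured compounds shares this change, so the expectation rests on the two values alone. Compound 1 sits at a limit rather than a number. Compound 2 gives 30000 nM, so the hydroxy-bearing ring seems to go with lower toxicity. Compound 3 is expected to move the same way, with an estimated step of a 2.7-fold higher number from compound 2 to compound 3 (0.43 log units; beyond the scatter). For compound 3 the estimated value is 80000 nM, expected between 25000 nM and 300000 nM, with a fair chance that only a limit is reported.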

Compound 3, minimum cytotoxic concentration: 12000 nM
Beside the measured number, compound 3's estimate is 6.7-fold (0.82 log units) above it; the measured number lies below the stated range.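

With the dodec-1-ynyl chain held fixed, the change from the 4-hydroxy-5-(hydroxymethyl)oxolan-2-yl ring to the 3,4-dihydroxy-5-(hydroxymethyl)oxolan-2-yl ring can now be read directly in this assay: hydroxy in place of hydrogen on this saturated ring carbon gives a 2.5-fold lower number from compound 2 to compound 3 (0.40 log units; beyond the scatter), so here the added hydroxy goes with higher toxicity in this test, not lower. With the ring held fixed instead, hexyl in place of hydrogen on a saturated chain carbon, four bonds along the chain from a triple-bonded carbon, gives an at least 12-fold lower number from compound 1 to compound 3 (1.07 log units; beyond the scatter), which shows that chain length alone moves the read-out by more than the ring hydroxy does. Compound 1 stands at a limit and not at a number, so that step has only a bound: the limit of > 144000 nM in this assay, at which 1 of the 3 values shown sits.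

As far as these compounds go, the hydroxy step is read on the dodec-1-ynyl chain alone, and whether it runs the same way on the hex-1-ynyl chain remains open. Also open, from the compounds shown here alone, is how an amine or a fluorine in place of this hydroxy, or a chain longer than dodec-1-ynyl, would read in this assay.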